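Hydroxy for acetamido on the aryl ring of compound 2

The source may report more compounds than this note shows. Statements on the series, on what has been measured and on what is new or still open speak of the compounds shown alone.

Among the measured compounds shown here, compound 2 `C=CC[C@H]1C[C@]2([C@@H](C)Cc3ccc(OC)c(NC(C)=O)c3)OCOC2=CC1=O` gives 310 nM in a functional assay on NCI-H460 cells (Homo sapiens) for antiproliferative activity, with a stated time of 72 h (a lower number here means a stronger inhibitor, a higher number a weaker inhibitor), the higher of the two numbers measured so far. Its nearest neighbour is compound 1 `C=CC[C@H]1C[C@]2([C@@H](C)Cc3ccc(OC)cc3)OCOC2=CC1=O`, which in this assay gives 90 nM; the two differ only by the acetamido group, and that step, a 3.4-fold higher number from compound 1 to compound 2 (0.54 log units; beyond the scatter), lies beyond the scatter.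

Compound 3 `C=CC[C@H]1C[C@]2([C@@H](C)Cc3ccc(OC)c(O)c3)OCOC2=CC1=O` is not yet measured. Relative to compound 2 the change is hydroxy in place of acetamido on an aromatic carbon. For the measured compounds named here, no measured pair shows hydroxy against acetamido or against hydrogen at this position, so the only bearing step is a 3.4-fold higher number from compound 1 to compound 2 (0.54 log units; beyond the scatter), which shows that occupying this position with acetamido raised the number modestly. Hydroxy is a far smaller substituent at the same site, so the outcome is expected to fall between the two measured numbers, a step of a 1.9-fold lower number from compound 2 to compound 3 (0.29 log units; within the scatter) being expected on the grounds that compound 1 gave 90 nM with hydrogen there. In this assay compound 3 is therefore estimated at 160 nM, with a range from 60 nM to 450 nM.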

Compound 3, half-maximal inhibitory concentration: 80 nM
The estimate for compound 3 lay 2.0-fold (0.30 log units) above the measured number, and the stated range covers the measured number.
By their numbers in this assay, from the lowest: compounds 3 and 1 (each within the scatter of the next); then compound 2.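

At the aromatic carbon ortho to a methoxy group, in this assay the rise seen with acetamido does not extend to every substituent: hydroxy in place of acetamido reverses it (a 3.9-fold lower number from compound 2 to compound 3 (0.59 log units; beyond the scatter)). Hydroxy in place of hydrogen gives a 1.1-fold lower number from compound 1 to compound 3 (0.05 log units; within the scatter) and so leaves the number within the scatter of the unsubstituted parent, which shows that this position can carry a hydroxy group without a readable change and that, among these three compounds, only acetamido stands apart. No measured property is available to account for the difference between acetamido and hydroxy at this carbon.

From the compounds shown here alone, whether a free amine or a second methoxy group at this carbon would read like hydroxy or like acetamido remains open, as does whether a longer acyl chain on the amide nitrogen would raise the number further. Going by these compounds, all three numbers also come from this assay alone, so whether hydroxy and hydrogen stay level at this position in any other cell line remains unknown.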